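The compounds below may be only part of what the source reports. "The series", "measured", "known", "first", "only" and "open" are said of these compounds alone.

In a functional assay on MCF7 cells (Homo sapiens) for cytotoxicity, read by MTT assay, with a stated time of 72 h (on this read-out lower numbers stand for stronger inhibition and higher numbers for weaker inhibition), compound 1 `O=C(c1ccccc1)c1sc(N2CCCC2)nc1Cl` gives 63000 nM and compound 2 `O=C(c1ccccc1)c1sc(N2CCCC2)nc1Br` gives 69000 nM so compound 2 stands within the scatter of compound 1. Compound 3 `O=C(c1ccccc1)c1sc(N2CCCCC2)nc1Br` keeps the bromo group and carries piperidin-1-yl in place of pyrrolidin-1-yl on an aromatic carbon is the whole difference. For the measured compounds named here, the one measured step, a 1.1-fold higher number from compound 1 to compound 2 (0.04 log units; within the scatter) for bromo in place of chloro, is small but does not touch this group, so in this assay no step beyond the scatter is expected. The estimated step is a 1.1-fold lower number from compound 2 to compound 3 (0.03 log units; within the scatter) on this reasoning. Compound 3 is expected at 65000 nM (estimated range 30000 nM to 130000 nM).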

Compound 3, half-maximal inhibitory concentration: 35000 nM
Beside the measured number, compound 3's estimate is 1.9-fold (0.27 log units) above it; low and high end bracket the measured number.
By their numbers in this assay, from the lowest: compounds 3, 1 and 2 (each within the scatter of the next).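

In this assay, the earlier step changed only the halogen, whereas this one tests the amine on the aromatic carbon next to the ring nitrogen and the ring sulfur: a 2.0-fold lower number from compound 2 to compound 3 (0.29 log units; within the scatter). With the bromo group kept, piperidin-1-yl in place of pyrrolidin-1-yl therefore leaves the number within the scatter, though the step lies close to its edge. Nothing available explains this result. The compounds shown leave open whether morpholin-4-yl or an open-chain amine such as diethylamino at this position would move the number beyond the scatter. They also leave open whether piperidin-1-yl would behave alike with the chloro group in place of the bromo group.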